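The source may hold more compounds than are shown below. What is called first, only, known or untested is meant among the compounds shown, and "the series" means these compounds.

Measured compounds:
compound 1, `CC(C)n1ncc2c(C(=O)Nc3ccncc3)cc(-c3cccs3)nc21`
compound 2, `CC(C)n1ncc2c(C(=O)Nc3ccc(F)c(F)c3)cc(-c3cccs3)nc21`
compound 3, `CC(C)n1ncc2c(C(=O)Nc3c(F)cc(F)cc3F)cc(-c3cccs3)nc21`

In an ADME assay on LLC-MK2 cells (Macaca mulatta) for cytotoxicity, read by spectrophotometry and crystal violet staining, with a stated time of 4 days (on this read-out higher numbers stand for lower toxicity in this test and lower numbers for higher toxicity in this test), compound 1 gives 6300 nM. For compound 2 this assay reports only a limit, > 200000 nM. For compound 3 the read-out is likewise a limit, > 200000 nM, so compound 3 stands at the least toxic end of what was seen, as does compound 2 (the limit of > 200000 nM in this assay, at which 2 of the 3 values shown sit). The step between them, a step that the two limits leave unreadable from compound 2 to compound 3, cannot be sized. Compound 4 is `CC(C)n1ncc2c(C(=O)Nc3cccnc3)cc(-c3cccs3)nc21`; it differs from compound 3 by pyridin-3-yl in place of 2,4,6-trifluorophenyl on an amide-type nitrogen.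

For the measured compounds named here, two measured steps bear on this change, both in the opposite direction: an at least 31-fold higher number from compound 1 to compound 2 (1.50 log units; beyond the scatter) and an at least 31-fold higher number from compound 1 to compound 3 (1.50 log units; beyond the scatter). Both show that replacing a pyridinyl amide substituent by a fluorinated phenyl makes the number far higher. Returning from 2,4,6-trifluorophenyl to a pyridinyl is therefore expected to lower the number by a large step, an at least 25-fold lower number from compound 3 to compound 4 (1.39 log units; beyond the scatter), bringing compound 4 close to compound 1. Compound 4 is estimated at 8000 nM, within 2000 nM to 60000 nM.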

Compound 4, half-maximal cytotoxic concentration: > 200000 nM
Compound 4: only a limit was reported; the forecaster's own chance of this, stated with the estimate: 15%; middle value at least 25-fold (1.39 log units) away from the limit.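

The result shows that a pyridinyl ring on the amide-type nitrogen does not by itself bring the low number of compound 1 in this assay: pyridin-3-yl in place of pyridin-4-yl gives an at least 31-fold higher number from compound 1 to compound 4 (1.50 log units; beyond the scatter). The two earlier steps could be read as a contrast between pyridinyl and fluorinated phenyl groups, but among the compounds shown the low number now belongs to pyridin-4-yl alone, and compound 4 goes against the wider reading. The steps among compound 2, compound 3 and compound 4 cannot be read, since each of these compounds has only a limit: the limit of > 200000 nM in this assay, at which 3 of the 4 values shown sit.

The compounds shown leave open how far each of these three compounds lies beyond that limit. They also leave open whether pyridin-2-yl or a pyrimidinyl ring on the same nitrogen would fall with compound 1 or with compound 4.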